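Notes on the step from compound 3 to compound 4

The source may report more compounds than this note shows. Statements on the series, on what has been measured and on what is new or still open speak of the compounds shown alone.

compound 1 `COc1ccc(-c2c(C)nc3c(N4CC[C@@H](NC(=O)OC5CCCCC5)C4)cc(C)nn23)cc1OC`: > 95%
compound 2 `COc1ccc(-c2c(C)nc3c(N4CC[C@@H](NS(=O)(=O)c5ccc(Cl)cc5)C4)cc(C)nn23)cc1OC`: > 95%
compound 3 `COc1ccc(-c2c(C)nc3c(N4CC[C@H](O)C4)cc(C)nn23)cc1OC`: > 95%

In an ADME assay on microsomes from liver (Mus musculus) for metabolic stability, read by LC-MS, with NADPH named in the record, with a stated time of 60 min, tested at 1 uM, in the absence of a further agent (a lower number here means that less of the compound is left, a higher number that more of the compound is left), compound 3 stands at > 95%, which is a limit and not a number. Among the measured compounds shown here, the series so far offers only (the limit of > 95% in this assay, at which 3 of the 3 values shown sit).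

Compound 4 `COc1ccc(-c2c(C)nc3c(N4CC[C@@H](SC(C)=O)C4)cc(C)nn23)cc1OC` carries 3-(acetylsulfanyl)pyrrolidin-1-yl in place of 3-hydroxypyrrolidin-1-yl on an aromatic carbon. For the measured compounds named here, no measured compound carries the entering group. Going by the values given here, the one measured step, a step that the two limits leave unreadable from compound 1 to compound 2, is a different exchange on an amine nitrogen and gives no size to carry over. The expectation in this assay therefore rests on the structural change alone and stays loose. Any readable step would run toward less compound left, and a moderate one is expected, with an estimated size of a number at least 20 percentage points lower from compound 3 to compound 4 (beyond the scatter). Compound 4 is expected at 75%, within an estimated range of 40% to 97%.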

Compound 4, percent of the compound remaining: > 95%
Compound 4: no number, only a limit (the forecaster's own chance of this, stated with the estimate: 30%); at least 20 percentage points between middle value and limit.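

In this assay compound 4 gives > 95% as a limit and not a number. Among the compounds shown here, no step from compound 1, compound 2 or compound 3 to compound 4 can be read: the limit of > 95% in this assay, at which 4 of the 4 values shown sit. The compounds shown leave open whether the exchanged groups differ at all in how much compound is left.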